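The compounds below may be only part of what the source reports. "The series", "measured", "known", "first", "only" and "open" are said of these compounds alone.

In a functional assay on A549 cells (Homo sapiens) for antiproliferative activity, read by MTT assay (a lower number here means a stronger inhibitor, a higher number a weaker inhibitor), the measured compounds are:
- compound 1 `Cc1nn2c(-c3nc4cc(Cl)c(Cl)cc4[nH]3)c(-c3ccccc3)nc2s1` at 13600 nM
- compound 2 `Cc1nn2c(-c3nc4cc(Cl)ccc4[nH]3)c(-c3ccccc3)nc2s1` at 16900 nM
- compound 3 `Cc1nn2c(-c3nc4cc(C(F)(F)F)ccc4[nH]3)c(-c3ccc(F)cc3)nc2s1` at 12700 nM

Compound 1 has no separation from the other two: its value lies within the scatter of both compound 2 and compound 3, so the series shows no real spread so far.

The next compound is compound 4 `Cc1nn2c(-c3nc4cc(Cl)c(Cl)cc4[nH]3)c(-c3ccc(F)cc3)nc2s1`. It differs from compound 1 by one change, fluoro in place of hydrogen on an aromatic carbon (fluoro in place of hydrogen on an aromatic carbon, phenyl to 4-fluorophenyl).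

Among the compounds with values here, no measured step covers this change. Within the data shown here, the only step available, a 1.2-fold higher number from compound 1 to compound 2 (0.09 log units; within the scatter), concerns a different place on the molecule and shows that removing a chloro leaves the number within the scatter. Compound 3 carries the same 4-fluorophenyl but has other substituents on the remaining part, and its value of 12700 nM is also within the scatter of compound 1. Nothing measured therefore points to a step in either direction, and none beyond the scatter is expected in this assay here.

The estimated step is small and is expected to stay within the scatter (a 1.1-fold lower number from compound 1 to compound 4 (0.04 log units; within the scatter)).

The estimate for compound 4 is 12500 nM with an expected range from 7000 nM to 22000 nM.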

Compound 4, half-maximal inhibitory concentration: > 30000 nM
Compound 4 ended at the assay's limit (the forecaster's own chance of this, stated with the estimate: 5%); middle value at least 2.4-fold (0.38 log units) from the limit.
By their numbers in this assay, from the lowest: compounds 3, 1 and 2 (each within the scatter of the next). At a limit, above all of these: compound 4.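

In this assay, within the data shown here, the change from phenyl to 4-fluorophenyl gives an at least 2.2-fold higher number from compound 1 to compound 4 (0.34 log units; beyond the scatter), the first step beyond the scatter, whereas removing a chloro elsewhere on the molecule gave only a 1.2-fold higher number from compound 1 to compound 2 (0.09 log units; within the scatter). The place para to a large group on this six-membered aromatic ring is therefore sensitive to a single fluoro in this pair, and the size of that step is only a lower bound because compound 4 stands at a limit of the assay, not at a number: the limit of > 30000 nM in this assay, at which 1 of the 4 values shown sits.

Compound 3 carries the same 4-fluorophenyl with a trifluoromethyl in place of the two chloro groups and gives 12700 nM, so it goes against any general link between this fluoro and a weak number, and the effect is established only for the pair of compound 1 and compound 4.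

Open, going by these compounds, is whether a chloro, a methoxy or an amine at this place on the phenyl would behave as fluoro does. Also open, on these data alone, is how far the result depends on the two chloro groups that compound 1 and compound 4 share.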